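The compounds below may be only part of what the source reports. "The series", "measured", "known", "first", "only" and "open" are said of these compounds alone.

Measured in a functional assay on SK-BR-3 cells (Homo sapiens) for cytotoxicity, read by sulforhodamine B assay, with a stated time of 72 h; a lower number here means that less compound is needed, a higher number that more compound is needed for the effect:

- compound 1 `COc1cc(OC)cc(-c2cc3occ(C)c3c(=O)o2)c1` gives 0.28 uM
- compound 2 `CCc1coc2cc(-c3cc(OC)cc(OC)c3)oc(=O)c12` gives 55.6 uM

Among the measured compounds shown here, compound 1 holds the lower of the two numbers, and nothing measured so far lies below it. The next compound to be tested is compound 3 `COc1cc(OC)cc(-c2cc3oc(C)c(C)c3c(=O)o2)c1`, which differs from compound 1 by a single change, methyl in place of hydrogen on an aromatic carbon, next to the ring oxygen and next to the ring atom that bears a methyl group.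

For the measured compounds named here, only one measured step bears on this change. It is a 200-fold higher number from compound 1 to compound 2 (2.30 log units; beyond the scatter), in which methyl takes the place of hydrogen on a saturated chain carbon bound to an aromatic carbon. That step lies at a different place on the molecule, so it is only a loose guide, but it shows that a small addition can move the number a long way in this assay. A rise is therefore expected here, though a smaller one, and the estimate is an 18-fold higher number from compound 1 to compound 3 (1.25 log units; beyond the scatter) in size. Compound 3 is expected to give 5 uM, within an estimated range of 0.6 uM to 40 uM.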

Compound 3, concentration for half-maximal effect: > 66.7 uM
Compound 3: only a limit was reported; the forecaster's own chance of this, stated with the estimate: 10%; at least 13-fold (1.12 log units) between middle value and limit.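

The first sentence of what this adds is about place: a methyl on an aromatic carbon of the five-membered aromatic ring, next to the ring oxygen and next to the ring atom that bears a methyl group, gives an at least 230-fold higher number from compound 1 to compound 3 (2.37 log units; beyond the scatter) and so carries the number far beyond the scatter. In this assay compound 3 gives > 66.7 uM as a limit and not a number, the only such reading among the compounds shown: the limit of > 66.7 uM in this assay, at which 1 of the 3 values shown sits. Set beside a 200-fold higher number from compound 1 to compound 2 (2.30 log units; beyond the scatter) as the other single methyl addition, this shows two separate places on compound 1 where one added methyl moves the number far upward, though one of the two steps ends in a limit and their order cannot be read.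

The compounds shown leave open whether any other group on this ring carbon, such as a fluorine atom, an amine or a carboxylic acid, keeps the number close to that of compound 1. They also leave open whether the same change gives a similar rise when the ring atom that bears a methyl group carries hydrogen instead.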